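Quinolinyl ether swap on the diol core: cytotoxicity notes

This account rests on a few compounds, and the source may have more. Where it says the series, first, only, none or still open, it means among the compounds named here.

Measured compounds:
- compound 1, `C=C1CC[C@H]2[C@@](C)(CCC(=O)[C@@]2(C)COC(C)=O)[C@@H]1C/C=C1/C(=O)OC[C@H]1Oc1c(Cl)cc(Cl)c2cccnc12`: 64700 nM in an ADME assay on Vero cells (Chlorocebus sabaeus) for cytotoxicity, read by MTT assay, with a stated time of 48 h; on this read-out lower numbers stand for higher toxicity in this test and higher numbers for lower toxicity in this test
- compound 2, `C=C1CC[C@@H]2[C@](C)(CO)[C@H](O)CC[C@@]2(C)[C@@H]1C/C=C1/C(=O)OC[C@@H]1Oc1cccc2ccc(C)nc12`: 99800 nM in this assay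
- compound 3, `C=C1CC[C@@H]2[C@](C)(COC(C)=O)[C@H](O)CC[C@@]2(C)[C@@H]1C/C=C1/C(=O)OC[C@@H]1Oc1cccc2ccc(C)nc12`: 46500 nM in this assay

Going by the values given here, compound 2 holds the highest number of the three; compound 1 sits within the scatter of it, while compound 3 lies beyond it, the only step measured being a 2.1-fold lower number from compound 2 to compound 3 (0.33 log units; beyond the scatter), acetyl for hydrogen on the oxygen.

Compound 4, `C=C1CC[C@@H]2[C@](C)(CO)[C@H](O)CC[C@@]2(C)[C@@H]1C/C=C1/C(=O)OC[C@@H]1Oc1ccnc2ccccc12`, differs from compound 2 only at the aryl ether: quinolin-4-yl in place of 2-methylquinolin-8-yl on an oxygen on a saturated carbon. Among the compounds with values here, no measured step touches that ring; the acetyl step from compound 2 to compound 3 concerns another place and does not bear. No movement beyond the scatter is therefore expected in this assay, and compound 4 is estimated at 90000 nM (range 40000 nM to 200000 nM), an expected step of a 1.1-fold lower number from compound 2 to compound 4 (0.04 log units; within the scatter).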

Compound 4, half-maximal cytotoxic concentration: 20700 nM
The estimate for compound 4 lay 4.3-fold (0.64 log units) above the measured number; measured number below the stated range.
By their numbers in this assay, from the lowest: compound 4; then compounds 3, 1 and 2 (each within the scatter of the next, the first and the last beyond it).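

The aryl ether on an oxygen on a saturated carbon is a place that moves the number in this assay: quinolin-4-yl in place of 2-methylquinolin-8-yl gives a 4.8-fold lower number from compound 2 to compound 4 (0.68 log units; beyond the scatter). Going by these compounds alone, until now, the only measured step lay elsewhere, at the acetyl on oxygen. Nothing available accounts for this step.

This single swap changes both the attachment point on the quinoline and the methyl group, and the two cannot be separated here. On these data alone, whether an amine or a carboxylic acid on the quinolin-4-yl ring would shift the number further remains open.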